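A few compounds are considered here, and "the series" means these few. Any claim that something is new, unique, unknown or untested is made for them only; others in the source may bear on it.

Measured compounds in a functional assay on BJAB cells (Homo sapiens) for antiproliferative activity, with a stated time of 4 days; a higher number here means that more compound is needed for the effect, a lower number that less compound is needed:

- compound 1 `Cc1ccc(-c2c(C)nn(-c3nc(-c4ccc(Cl)c(Cl)c4)c(SC(C)C)s3)c2C(=O)O)cc1` gives 3800 nM
- compound 2 `Cc1nn(-c2nc(-c3ccc(Cl)c(Cl)c3)c(SC(C)C)s2)c(C(=O)O)c1-c1cnccn1` gives 14000 nM
- compound 3 `COc1cc(Cl)cc(-c2c(C)nn(-c3nc(-c4ccc(Cl)c(Cl)c4)c(SC(C)C)s3)c2C(=O)O)c1` gives 760 nM

Compound 3 holds the lowest number of the three in this assay. The gaps that separate it from the other two are a 5.0-fold lower number from compound 1 to compound 3 (0.70 log units; beyond the scatter) and an 18-fold lower number from compound 2 to compound 3 (1.27 log units; beyond the scatter); both lie beyond the scatter. The three measured compounds differ from one another only in the aryl group on an aromatic carbon of the five-membered aromatic ring with 2 nitrogen in the shared core.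

Compound 4 `COc1ccc(C)cc1-c1c(C)nn(-c2nc(-c3ccc(Cl)c(Cl)c3)c(SC(C)C)s2)c1C(=O)O` changes that same position: 2-methoxy-5-methylphenyl in place of 3-chloro-5-methoxyphenyl on an aromatic carbon. Among the measured compounds shown here, the steps that bear on this are the aryl exchanges already measured at this carbon: a 3.7-fold higher number from compound 1 to compound 2 (0.57 log units; beyond the scatter), a 5.0-fold lower number from compound 1 to compound 3 (0.70 log units; beyond the scatter) and an 18-fold lower number from compound 2 to compound 3 (1.27 log units; beyond the scatter). For the measured compounds named here, every exchange at this position so far has moved the number beyond the scatter, in either direction, so a shift beyond the scatter is the likelier outcome here too. Nothing measured carries the 2-methoxy-5-methylphenyl pattern, so the direction is not fixed by the data; since compound 3 already stands lowest, a move back toward the level of compound 1, which gives 3800 nM, is taken as more probable than a further drop.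

Compound 4 is therefore expected at 2000 nM, within 600 nM to 6000 nM in this assay. This expectation amounts to a step of a 2.6-fold higher number from compound 3 to compound 4 (0.42 log units; beyond the scatter).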

Compound 4, half-maximal effective concentration: 9500 nM
For compound 4 the middle estimate is 4.8-fold (0.68 log units) below the measured one; the measured number lies above the stated range.
By their numbers in this assay, from the lowest: compound 3; then compound 1; then compounds 4 and 2 (each within the scatter of the next).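

In this assay, the step of a 13-fold higher number from compound 3 to compound 4 (1.10 log units; beyond the scatter) shows that the number at this carbon is not set by the counts computed for the aryl group: 3-chloro-5-methoxyphenyl and 2-methoxy-5-methylphenyl have the same heavy-atom, donor and acceptor counts, yet they lie far apart. Two substituents on the phenyl ring also carry no single direction, since a 2.5-fold higher number from compound 1 to compound 4 (0.40 log units; beyond the scatter) runs against the lower number of compound 3 relative to the 4-methylphenyl of compound 1. In addition, a 1.5-fold lower number from compound 2 to compound 4 (0.17 log units; within the scatter) shows that a six-membered aromatic ring of carbon only does not by itself separate compound 4 from the pyrazin-2-yl of compound 2, so the large gap seen earlier between compound 2 and compound 3 belongs to compound 3's particular aryl group and not to the carbon-only ring as such.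

Compounds 3 and 4 differ in both the identity and the arrangement of their substituents, so the compounds shown cannot assign the gap to the chlorine, the methyl or the methoxy placement, and they leave open how an amine or a longer alkoxy chain on this phenyl ring would behave. Nothing available here bears on the reason for any of these steps.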